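The source may hold more compounds than are shown below. What is called first, only, known or untested is meant among the compounds shown, and "the series" means these compounds.

Measured so far:
compound 1 `COc1cc(/C=C/c2ccc(C(C)C)cc2)cc(OC)c1OC`, 18.4 uM
compound 2 `COc1cc(/C=C/c2ccc(C(C)(C)C)cc2)cc(OC)c1OC`, > 25 uM
compound 3 `CCOc1ccc(/C=C\c2cc(OC)c(OC)c(OC)c2)cc1`, 9.6 uM

Compound 1 gives 18.4 uM in a functional assay on MCF7 cells (Homo sapiens) for cytotoxicity; a lower number here means that less compound is needed, a higher number that more compound is needed for the effect. For compound 2 the reported value is a limit and not a number: it sits at the limit of > 25 uM in this assay, at which 1 of the 3 values shown sits. The change from compound 1 to compound 2 is methyl in place of hydrogen on a saturated chain carbon bound to an aromatic carbon and two saturated chain carbons, and it made an at least 1.3-fold higher number from compound 1 to compound 2 (0.13 log units; that floor lies within the scatter). Compound 3 gives 9.6 uM; the difference between its core and the core of compound 1 is not broken down here.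

Compound 4 `CCCOc1ccc(/C=C\c2cc(OC)c(OC)c(OC)c2)cc1` is not yet measured. It differs from compound 3 by methyl in place of hydrogen on a saturated chain carbon, two bonds along the chain from an oxygen on an aromatic ring, the same kind of change as from compound 1 to compound 2, though the place differs: here the carbon is two bonds along the chain from an oxygen on an aromatic ring, there it was bound to an aromatic carbon and two saturated chain carbons. Resting on an at least 1.3-fold higher number from compound 1 to compound 2 (0.13 log units; that floor lies within the scatter), which stayed within the scatter, compound 4 is expected to show roughly a 1.3-fold higher number from compound 3 to compound 4 (0.10 log units; within the scatter) in this assay. The estimate for compound 4 is 12 uM, between 5 uM and 30 uM.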

Compound 4, concentration for half-maximal effect: 6.6 uM
Compound 4: the middle estimate sits 1.8-fold (0.26 log units) above what was measured; the measured number falls inside the stated range.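

Going from ethoxy to propoxy in this assay made a 1.5-fold lower number from compound 3 to compound 4 (0.16 log units; within the scatter) and, taken alone, this step cannot be told apart from the differences between repeated measurements. Set beside the same methyl-for-hydrogen change at a different place on the other core, the two results read: the same change on two cores in this assay, an at least 1.3-fold higher number (0.13 log units; that floor lies within the scatter) from compound 1 to compound 2 and a 1.5-fold lower number (0.16 log units; within the scatter) from compound 3 to compound 4; the limit leaves it open whether they differ. Compound 2 gives > 25 uM as a limit and not a number, and the two steps show neither that this change carries over from one core to the other nor that it fails to.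

The compounds shown leave open what a butoxy chain or a chain bearing an amine would do in place of propoxy. They also leave open whether a methyl added at other places would give a step beyond the scatter.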